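A few compounds are considered here, and "the series" means these few. Any claim that something is new, unique, unknown or untested is made for them only; others in the source may bear on it.

Measured compounds:
compound 1 `Brc1ccc2ccn(CCN3CCNCC3)c2c1` — 61%
compound 2 `CN1CCCN(CCn2ccc3cc(Br)ccc32)CC1` — 65%
compound 3 `CN1CCCN(CCn2ccc3ccc(N)cc32)CC1` — 0%

In an assay on HEK293 cells for binding affinity to 5-hydroxytryptamine receptor 7 (Homo sapiens), read by radioligand binding, tested at 1 uM (a higher number here means more inhibition at the concentration tested (going by the name of the read-out), a lower number less inhibition), compound 3 gives 0% and stands lowest of the three numbers. Its nearest neighbour is compound 1, whose 61% lies well beyond the scatter above it, and compound 2 sits further still, with 65%. Neither compound 1 nor compound 2 carries the amino group that compound 3 bears on its aromatic ring, and both give a clearly higher inhibition than compound 3.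

Compound 4 `C=C(C)c1ccc2ccn(CCN3CCCN(C)CC3)c2c1` has not yet been measured in this assay. It differs from compound 3 in one place: 1-methylethenyl in place of amino on an aromatic carbon. The basic side chain and the shared core are unchanged.

Within the data shown here, no step between measured compounds is available to calibrate this particular change. Among the measured compounds shown here, since compound 3 is the only compound with an amino group and the only one reading at zero, while the compounds without it, compound 1 and compound 2, read far higher, an upward step of considerable size, clearly beyond the scatter, is expected on going from compound 3 to compound 4 in this assay, namely a number 50 percentage points higher from compound 3 to compound 4 (beyond the scatter). Compound 4 is therefore estimated to give 50%, within a range from 20% to 80%.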

Compound 4, a percentage reported as inhibition, at one concentration (the size of the read-out at that concentration, not a potency): 72%
Estimate against measurement, compound 4: 22 percentage points below; measured number inside the range.
By their numbers in this assay, from the lowest: compound 3; then compounds 1, 2 and 4 (each within the scatter of the next, the first and the last beyond it).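

In this assay, putting 1-methylethenyl in place of amino on an aromatic carbon, meta to a fused ring and para to a fused ring, gives a number 72 percentage points higher from compound 3 to compound 4 (beyond the scatter), while the side chain and the shared core stay the same. The zero reading of compound 3 therefore does not mean that this position rejects every substituent: with a group of 3 carbon atoms and 0 hydrogen-bond donors at the same place, compound 4 gives 72%. The result ties the low reading to the amino group at this position rather than to the rest of compound 3, but nothing shown explains why the exchange has so large an effect.

The compounds shown leave open whether the double bond of 1-methylethenyl matters, which an isopropyl group at the same place would test, or whether any small carbon group, such as methyl, would do as well. They also leave open whether a hydroxyl or methoxy group there would read nearer to compound 3 or to compound 4, and whether an acetylated amine would restore the reading lost with the free amino group.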